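The source may report more compounds than this note shows. Statements on the series, on what has been measured and on what is new or still open speak of the compounds shown alone.

Of the compounds shown here, three that share one core have been measured in an assay on cells for positive allosteric modulation of Cystic fibrosis transmembrane conductance regulator variant F508del (Homo sapiens), with stated times of 10 min and 7 s, in the presence of a further agent that is not named here; a higher number here means that more compound is needed for the effect, a lower number that less compound is needed. Compound 1 `CC1(C)Cc2c(sc(NC(=O)Cc3ccn[nH]3)c2C(N)=O)C(C)(C)O1` gives 136 nM. Compound 2 `CC1(C)Cc2c(sc(NC(=O)C(C)(C)O)c2C(N)=O)C(C)(C)O1` gives 16 nM, and compound 3 `Cc1cc(C(=O)Nc2sc3c(c2C(N)=O)CC(C)(C)OC3(C)C)[nH]n1` gives 13 nM. Compound 3 therefore has the lowest number of the three, although its gap to compound 2 lies within the scatter; the step of a 1.2-fold lower number from compound 2 to compound 3 (0.09 log units; within the scatter) is within the scatter, whereas the step of a 10-fold lower number from compound 1 to compound 3 (1.02 log units; beyond the scatter) is large and the step of an 8.5-fold lower number from compound 1 to compound 2 (0.93 log units; beyond the scatter) is modest.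

Compound 4 `Cc1n[nH]c(C(=O)Nc2sc3c(c2C(N)=O)CC(C)(C)OC3(C)C)c1Cl` differs from compound 3 in one place: chloro in place of hydrogen on an aromatic carbon, on an aromatic carbon of a five-membered aromatic ring with 2 nitrogen, next to the ring atom that bears a methyl group. Within the data shown here, none of the measured steps adds a chloro group, so they bear on this change only loosely. The steps of a 10-fold lower number from compound 1 to compound 3 (1.02 log units; beyond the scatter) and a 1.2-fold lower number from compound 2 to compound 3 (0.09 log units; within the scatter) show that the 3-methyl-1H-pyrazol-5-yl group on the carbonyl carbon serves well, but they say nothing about a halogen on that ring. A step of no more than the scatter is therefore expected, in either direction. Compound 4 is expected to give 10 nM, in a range from 4 nM to 30 nM. This estimate means a step of a 1.3-fold lower number from compound 3 to compound 4 (0.11 log units; within the scatter), expected to stay within the scatter.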

Compound 4, half-maximal effective concentration: 11 nM
Beside the measured number, compound 4's estimate is 1.1-fold (0.04 log units) below it, within the range that was stated.
By their numbers in this assay, from the lowest: compounds 4, 3 and 2 (each within the scatter of the next); then compound 1.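

A chloro group is accepted on this aromatic carbon of the five-membered aromatic ring with 2 nitrogen, next to the ring atom that bears a methyl group: the step of a 1.2-fold lower number from compound 3 to compound 4 (0.07 log units; within the scatter) means that this assay cannot tell the two compounds apart. The chloro-bearing ring also stays level with the 1-hydroxy-1-methylethyl group, with a step of a 1.5-fold lower number from compound 2 to compound 4 (0.16 log units; within the scatter), and it keeps the wide distance from the (1H-pyrazol-5-yl)methyl group, with a step of a 12-fold lower number from compound 1 to compound 4 (1.09 log units; beyond the scatter) on the carbonyl carbon. No measurement shown here gives a reason why this place accepts the chloro group.

One substituent on one ring carbon says little about how much room for variation this place offers, so a fluoro, bromo, nitrile or methoxy group here could give a quite different number. From the compounds shown here alone, it also remains unknown whether the chloro group would behave the same way without the neighbouring methyl group, or with an ethyl or a cyclopropyl group in its place.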